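The compounds below may be only part of what the source reports. "The series", "measured", "known", "first", "only" and "open" are said of these compounds alone.

Compound 2 `CN1CCN(c2ccc(Nc3ncc(Cl)c(NCc4ccc(C(F)(F)F)cc4)n3)nc2)CC1` gives 7960 nM in a functional assay on Jurkat cells (Homo sapiens) for inhibition, read by CCK-8 assay, with a stated time of 48 h (on this read-out higher numbers stand for weaker inhibition of growth and lower numbers for stronger inhibition of growth), the lowest of the two numbers recorded; compound 1 `Cc1ccccc1Nc1nc(Nc2ccc(N3CCCN(C)CC3)cc2)ncc1Cl` gives 11300 nM in this assay, and the gap between them lies within the scatter. Compound 3 `COc1ccc(Nc2nc(Nc3ccc(N4CCN(C)CC4)cn3)ncc2Cl)cc1` differs from compound 2 in one place: 4-methoxyphenyl in place of 4-(trifluoromethyl)benzyl on a nitrogen on an aromatic ring. Going by the values given here, no measured step of this kind is available, so the expected step of a 1.3-fold lower number from compound 2 to compound 3 (0.12 log units; within the scatter) is a small one, not beyond the scatter, with no firm direction. Compound 3 is therefore estimated at 6000 nM in this assay, in a range from 1500 nM to 25000 nM.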

Compound 3, concentration for 50% growth inhibition: 11200 nM
Beside the measured number, compound 3's estimate is 1.9-fold (0.27 log units) below it, within the range that was stated.
By their numbers in this assay, from the lowest: compounds 2, 3 and 1 (each within the scatter of the next).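

At this nitrogen on an aromatic ring, 4-methoxyphenyl in place of 4-(trifluoromethyl)benzyl gives in this assay a 1.4-fold higher number from compound 2 to compound 3 (0.15 log units; within the scatter) and so shows no change that can be told from the scatter. A benzyl group and a directly attached phenyl group, with their different substituents, are thus both seen at this position with numbers that cannot be separated. No measured evidence accompanies this step to explain it.

As far as these compounds go, whether a simple alkyl amine, such as cyclohexylamine, or a pyridine ring at this nitrogen would give a step beyond the scatter stays open. So does whether the same exchange would give a similar result with a different group on the shared core.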